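Swapping a Five-Membered Ring for Morpholine

A few compounds are considered here, and "the series" means these few. Any claim that something is new, unique, unknown or untested is made for them only; others in the source may bear on it.

Compound 1 `Cc1cccc(/C(N)=N/NC(=S)N2CCN(c3ccccn3)CC2)n1`: 86.3%
Compound 2 `N/C(=N\NC(=S)N1CCCC1)c1ccc(F)cn1`: 81.2%
Compound 3 `Cc1cccc(/C(N)=N/NC(=S)N2CCCCC2)n1`: 83.5%

These three numbers come from a functional assay on HeLa cells (Homo sapiens) for cytotoxicity, read by MTT assay, with a stated time of 72 h, tested at 30 uM; a higher number here means more inhibition of growth at the concentration tested, a lower number less inhibition of growth. Compound 2 carries the smallest of them, but the gap to compound 3 and the gap to compound 1 both fall within the usual scatter of this measurement, so the three compounds cannot be separated on this evidence. Compound 4 `N/C(=N\NC(=S)N1CCOCC1)c1ccc(F)cn1` has not been measured. It differs from compound 2 in one place: morpholin-4-yl in place of pyrrolidin-1-yl on a thiocarbonyl carbon. Among the compounds with values here, no pair among the measured compounds shows what this kind of exchange does, so there is no measured step to lean on. The expectation is therefore a shift of no more than the scatter, with the estimated step of a number 5.2 percentage points lower from compound 2 to compound 4 (within the scatter) in this assay. Compound 4 is expected to give about 76%, most likely between 60% and 90%.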

Compound 4, percent growth inhibition at one concentration: 84.5%
The estimate for compound 4 lay 8.5 percentage points below the measured number; measured number inside the range.
By their numbers in this assay, from the lowest: compounds 2, 3, 4 and 1 (each within the scatter of the next).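

In this assay the exchange gives a number 3.3 percentage points higher from compound 2 to compound 4 (within the scatter) when morpholin-4-yl replaces pyrrolidin-1-yl on a thiocarbonyl carbon. Within the data shown here, this is the first measured step at this position, and it shows that a six-membered ring holding an oxygen can stand here in place of a five-membered ring without a separable change in growth inhibition. No supporting measurement bears on why compound 2 and compound 4 read alike.

Still open, going by these compounds, is whether an open-chain dimethylamino group, or a carboxylic acid carried on the ring, would also leave the reading unchanged. A single tested concentration also leaves open whether compound 2 and compound 4 would differ at lower concentrations.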